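Side-chain exchange in a series of EP3 antagonists

This account rests on a few compounds, and the source may have more. Where it says the series, first, only, none or still open, it means among the compounds named here.

Measured so far:
compound 1 `CC(C)NC(=O)CC(c1ccc(-c2ccc3cccc(F)c3c2)[nH]c1=O)C(C)C` gives 15 nM
compound 2 `CCn1ncc2c(F)cc(-c3ccc(C(CC)(CC)c4ncn(C)n4)c(=O)[nH]3)cc21` gives 96 nM

Both numbers come from a functional assay on CHO cells for antagonist activity at prostaglandin E2 receptor EP3 subtype (Homo sapiens), read by cAMP accumulation; a lower number here means a stronger inhibitor, a higher number a weaker inhibitor. Among the measured compounds shown here, compound 1 holds the lowest value of the two; compound 2, its only neighbour, sits at a clearly higher number, and the gap between them lies beyond the usual scatter. The two compounds differ in several places at once, so nothing is drawn from that gap about any single group.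

The next compound, compound 3 `CC(C)C(c1ccc(-c2ccc3cccc(F)c3c2)[nH]c1=O)N1CCNC1=O`, keeps the core of compound 1 and changes one group: 2-oxoimidazolidin-1-yl in place of (isopropylcarbamoyl)methyl on a saturated chain carbon bound to an aromatic carbon and a saturated chain carbon. For the measured compounds named here, no pair of measured compounds shows the effect of this exchange, so the expectation rests only on compound 1. Given the value of compound 1, 15 nM, the step of a 2.7-fold higher number from compound 1 to compound 3 (0.43 log units; beyond the scatter) is expected to be a modest rise in number, around the edge of the scatter. Compound 3 is thus estimated at 40 nM, with a likely range from 10 nM to 160 nM.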

Compound 3, half-maximal inhibitory concentration: 28 nM
Compound 3: the middle estimate sits 1.4-fold (0.15 log units) above what was measured; measured number inside the range.
By their numbers in this assay, from the lowest: compounds 1 and 3 (each within the scatter of the next); then compound 2.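

In this assay, 2-oxoimidazolidin-1-yl in place of (isopropylcarbamoyl)methyl on a saturated chain carbon bound to an aromatic carbon and a saturated chain carbon gives a 1.9-fold higher number from compound 1 to compound 3 (0.27 log units; within the scatter), so this position accepts either the open chain or the five-membered non-aromatic ring without a separation between the two numbers. The two groups also match in their counts of hydrogen-bond donors and acceptors, so this pair says nothing about what happens at this carbon when those counts change. No measured property bears on this result, and it offers no explanation for it.

Open, as far as these compounds go, is whether a carboxylic acid, a primary amine or a plain alkyl chain at this carbon would stay within the scatter of these two compounds. Also open, from the compounds shown here alone, is whether the same exchange would give a similar step on another core.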